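Swapping Thiophene for Pyrrole in an Antiproliferative Amide Series

The source may hold more compounds than are shown below. What is called first, only, known or untested is meant among the compounds shown, and "the series" means these compounds.

Of the compounds shown here, two sharing one core have been measured in a functional assay on A-375 cells (Homo sapiens) for antiproliferative activity; on this read-out higher numbers stand for weaker inhibition and lower numbers for stronger inhibition. Compound 1 `O=C(Nc1ccc(-c2ccco2)cc1)C1CCCN(Cc2ccc(F)c(F)c2)C1` gives 1040 nM, and compound 2 `O=C(Nc1ccc(-c2cccs2)cc1)C1CCCN(Cc2ccc(F)c(F)c2)C1` gives 390 nM. The step of a 2.7-fold lower number from compound 1 to compound 2 (0.43 log units; beyond the scatter) is the only one in hand, and on these two numbers compound 2 stands with the lower value, beyond the scatter. Compound 3 `O=C(Nc1ccc(-c2ccc[nH]2)cc1)C1CCCN(Cc2ccc(F)c(F)c2)C1` keeps the core and alters the same five-membered ring once more: 1H-pyrrol-2-yl in place of thiophen-2-yl on an aromatic carbon. Among the measured compounds shown here, only the step from compound 1 to compound 2 bears on this change; it was modest and it concerned a different exchange in that ring, so it guides direction only loosely. The pyrrole brings a hydrogen-bond donor, which neither measured ring has, leaving the outcome open. A modest rise in this assay is expected, about a 2.1-fold higher number from compound 2 to compound 3 (0.31 log units; beyond the scatter). Compound 3 is therefore estimated at 800 nM, within 250 nM to 2500 nM.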

Compound 3, half-maximal inhibitory concentration: 360 nM
Beside the measured number, compound 3's estimate is 2.2-fold (0.35 log units) above it; low and high end bracket the measured number.
By their numbers in this assay, from the lowest: compounds 3 and 2 (each within the scatter of the next); then compound 1.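

In this assay the change to 1H-pyrrol-2-yl gives a 1.1-fold lower number from compound 2 to compound 3 (0.03 log units; within the scatter) and so does not separate the two rings, even though the hydrogen-bond counts differ: thiophen-2-yl has one acceptor and no donor, and 1H-pyrrol-2-yl has one donor and no acceptor. Among the three five-membered rings at this position, on an aromatic carbon para to a large group, furan-2-yl alone stands apart, with a 2.9-fold lower number from compound 1 to compound 3 (0.46 log units; beyond the scatter) showing that the pyrrole, like the thiophene, reads beyond the scatter of it. Nothing in hand explains why these rings compare as they do.

Open, as far as these compounds go, is whether the pyrrole hydrogen plays any part, which a 1-methylpyrrol-2-yl ring would test. Also open, from the compounds shown here alone, is how a six-membered pyridine ring or an open-chain amine would read at this position.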